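The source may report more compounds than this note shows. Statements on the series, on what has been measured and on what is new or still open speak of the compounds shown alone.

The measured compounds:
Compound 1, `CCOC(=O)[C@@H](N)CCC(=O)NCCSC(=O)C(C)(C)C`: in an ADME assay on liver for metabolic stability, with liver carboxylesterase 1 (Homo sapiens) as the target (a lower number here means that the compound disappears faster, a higher number that the compound lasts longer), compound 1 gives 0.167 h.
Compound 2, `CCCOC(=O)[C@@H](N)CCC(=O)NCCSC(C)=O`: in this assay compound 2 gives 0.167 h.
Compound 3, `CCCCOC(=O)[C@@H](N)CCC(=O)NCCSC(C)=O`: in this assay compound 3 gives 0.167 h.

Compound 3 stands level with compounds 1 and 2 in this assay, all three reading the same. Compound 4, `CCOC(=O)[C@@H](N)CCC(=O)NCCSC(C)=O`, differs from compound 3 by hydrogen in place of ethyl on a saturated chain carbon, two bonds along the chain from an oxygen next to a carbonyl group, which read one bond further out is butyl to ethyl. Within the data shown here, the only measured step of this kind, no change at the digits printed from compound 2 to compound 3 (within the scatter), lengthened the same chain and left the half-life unchanged; the new step shortens that chain. Compound 1 carries the same ethyl chain as compound 4 and reads the same as compounds 2 and 3. Because no change at the digits printed from compound 2 to compound 3 (within the scatter) shows no change, compound 4 is expected to show none beyond the scatter in this assay, the expected step being no change at the digits printed from compound 3 to compound 4 (within the scatter). Compound 4 is therefore estimated at 0.167 h, between 0.08 h and 0.35 h.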

Compound 4, half-life in the liver carboxylesterase 1 assay: 0.167 h
Estimate against measurement, compound 4: no gap at the digits printed, within the range that was stated.
By their numbers in the liver carboxylesterase 1 assay, from the lowest: compounds 1, 2, 3 and 4 (each within the scatter of the next).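

In the liver carboxylesterase 1 assay, the chain at this position can go from butyl to ethyl, giving no change at the digits printed from compound 3 to compound 4 (within the scatter), or from propyl to ethyl, giving no change at the digits printed from compound 2 to compound 4 (within the scatter), and the half-life does not respond. Methyl in place of tert-butyl on a carbonyl carbon, at the other end of the molecule, likewise gives no change at the digits printed from compound 1 to compound 4 (within the scatter). In a physicochemical assay for lipophilicity, measured as octanol-water partition, at pH 2 (on this read-out lower numbers stand for lower lipophilicity and higher numbers for higher lipophilicity), compound 3 gives 0.43 and compound 4 gives 0.11. Yet butyl to ethyl is not a silent change, since in the physicochemical assay it lowers the partition coefficient: the measured partition coefficient of compound 3, 0.43, and of compound 4, 0.11, a number 0.32 log units lower (beyond the scatter)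

On these data alone, whether a carboxylic acid or a branched chain such as isopropyl at this position would shift the half-life remains open. So does whether a chain longer than butyl would.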